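Methoxy in place of bromo: compound 3 to compound 4

The source may report more compounds than this note shows. Statements on the series, on what has been measured and on what is new or still open speak of the compounds shown alone.

Three amides of the shared core have been run in a functional assay on the whole organism (integument) for inhibition, with Chilo suppressalis as the target, read by scintillation counting, with a stated time of 72 h; a higher number here means a weaker inhibitor, a lower number a stronger inhibitor. Compound 1 `O=C(Nc1nnc(-c2ccc(Cl)cc2)s1)c1ccccc1` is the unsubstituted parent; in this assay compound 1 gives > 5010 nM, which is a limit of the assay and not a number. Compound 2 `O=C(Nc1nnc(-c2ccc(Cl)cc2)s1)c1c(F)cccc1F` carries fluoro; in this assay compound 2 gives > 5010 nM, again a limit. Compound 3 `O=C(Nc1nnc(-c2ccc(Cl)cc2)s1)c1ccccc1Br` carries bromo; in this assay compound 3 gives > 5010 nM, also a limit. For the measured compounds named here, the one single-point step so far, a step that the two limits leave unreadable from compound 1 to compound 3, cannot be read because the limit of > 5010 nM in this assay, at which 3 of the 3 values shown sit, places both of its ends at the same limit.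

Compound 3 therefore stands at the limit, not distinguishable from the other two. The step to compound 4 `COc1ccccc1C(=O)Nc1nnc(-c2ccc(Cl)cc2)s1` is methoxy in place of bromo on an aromatic carbon. Going by the values given here, the only measured step that bears on it is a step that the two limits leave unreadable from compound 1 to compound 3, and that one is unreadable; no member of the series has yet left the limit, so no direction can be read from the numbers. For compound 4 in this assay the expectation is a value around 8000 nM, with a range from 3000 nM to 30000 nM, most probably reported once more as a limit. The expected step that the limit leaves unreadable from compound 3 to compound 4 is accordingly none beyond the scatter.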

Compound 4, half-maximal inhibitory concentration: 53.7 nM
The estimate for compound 4 lay 150-fold (2.17 log units) above the measured number; the whole stated range lies above it.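

Methoxy is the first group at this place, on an aromatic carbon ortho to a large group, to bring the series off its limit in this assay, giving an at least 93-fold lower number from compound 3 to compound 4 (1.96 log units; beyond the scatter) and an at least 93-fold lower number from compound 1 to compound 4 (1.96 log units; beyond the scatter). Hydrogen and bromo at this same place both leave the number at the limit, so the outcome here depends on which group is present and not merely on the place being filled. Both step sizes are bounds and the true gaps may be larger, since each starts from a limit: the limit of > 5010 nM in this assay, at which 3 of the 4 values shown sit.

The compounds shown leave open whether the gain belongs to the oxygen, the methyl or the whole methoxy group. Hydroxy, methyl, ethoxy or a dimethylamino group at this place would bear on that, and a single readable value gives no trend yet.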